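Carbamoyl in place of benzyl on compound 3

The source may report more compounds than this note shows. Statements on the series, on what has been measured and on what is new or still open speak of the compounds shown alone.

Compound 1 `CC(C)=CCC1Cc2c(OCc3ccccc3)cc(=O)n(CCCO)c2CC1(C)C` gives 11.1% in a functional assay on PANC-1 cells (Homo sapiens) for inhibition, read by MTT assay, with a stated time of 24 h, tested at 10 uM; a lower number here means less inhibition, a higher number more inhibition at the concentration tested (going by the name of the read-out).
Compound 2 `CC(C)=CCC1Cc2c(OC(=O)Nc3ccccc3F)cc(=O)n(CCCO)c2CC1(C)C` gives 0% in this assay.
Compound 3 `CC(C)=CCC/C(C)=C/CC1Cc2c(OCc3ccccc3)cc(=O)n(CCCO)c2CC1(C)C` gives 1.5% in this assay.

Compound 3 sits second of the three numbers, but its gaps to both neighbours are within the scatter: the step of a number 9.6 percentage points lower from compound 1 to compound 3 (within the scatter) is within the scatter, and compound 2 lies still closer. For the measured compounds named here, only the step of a number 11.1 percentage points lower from compound 1 to compound 2 (beyond the scatter) is beyond the scatter, and it was modest.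

Compound 4 `CC(C)=CCC/C(C)=C/CC1Cc2c(OC(=O)Nc3ccc(F)c(Cl)c3)cc(=O)n(CCCO)c2CC1(C)C` has not been measured. It differs from compound 3 in one place: (3-chloro-4-fluorophenyl)carbamoyl in place of benzyl on an oxygen on an aromatic ring. Going by the values given here, the one measured step that bears on this is the step from compound 1 to compound 2, where a fluorophenyl carbamoyl also replaced benzyl on the same oxygen, and a number 11.1 percentage points lower from compound 1 to compound 2 (beyond the scatter). Compound 3 already starts close to the lower end of the read-out, so the room for a comparable drop is small. A step of about a number 0.5 percentage points lower from compound 3 to compound 4 (within the scatter) is therefore expected, downward or none beyond the scatter. Compound 4 is estimated at 1% in this assay, with a likely range from 0% to 9%.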

Compound 4, a percentage reported as inhibition, at one concentration (the size of the read-out at that concentration, not a potency): 0%
For compound 4 the middle estimate is 1 percentage points above the measured one, within the range that was stated.
By their numbers in this assay, from the lowest: compounds 2, 4, 3 and 1 (each within the scatter of the next, the first and the last beyond it).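

On the background of compound 3, which carries the 3-methylbut-2-en-1-yl addition, placing (3-chloro-4-fluorophenyl)carbamoyl in place of benzyl on the oxygen gives a number 1.5 percentage points lower from compound 3 to compound 4 (within the scatter) in this assay, so the two compounds cannot be told apart. On this background, the swap does not reproduce the beyond-scatter size of a number 11.1 percentage points lower from compound 1 to compound 2 (beyond the scatter), but with compound 3 at only 1.5%, the read-out leaves almost no room for a drop, and the carbamoyl brings no recovery of inhibition at the concentration tested. No measurement at hand accounts for this result.

The compounds shown leave open whether any group on this oxygen can raise inhibition on this background. An acetyl group, or an amine or a carboxylic acid on the phenyl ring of the carbamoyl, could test that.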